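Swapping a tert-butyl cap for a piperidinylmethyl cap

A few compounds are considered here, and "the series" means these few. Any claim that something is new, unique, unknown or untested is made for them only; others in the source may bear on it.

Measured compounds:
- compound 1 `Cc1ccc(CNC(=O)[C@H](CCc2ccccc2)NC(=O)[C@H](CNC(=O)CC(C)(C)C)NC(=O)C(=O)c2c[nH]c3ccccc23)cc1`: "not determined" (no result reported)
- compound 2 `CC(C)(C)CNC(=O)C[C@H](NC(=O)C(C)(C)C)C(=O)N[C@@H](CCc1ccccc1)C(=O)NCc1ccccc1`: 62 nM

For the measured compounds named here, compound 2 is the only compound with a reported number in an assay on HEK293 cells for inhibition of nuclear factor NF-kappa-B complex (Homo sapiens), read by a luciferase reporter, with stated times of 1 h and 3 h (a higher number here means a weaker inhibitor, a lower number a stronger inhibitor), where compound 2 gives 62 nM. Going by the values given here, compound 1 carries no number in this assay, so the two cannot be compared, and no pair of measured compounds differs in a single place.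

The step of interest leads to compound 3 `CC(C)(C)CNC(=O)C[C@H](NC(=O)CN1CCCCC1)C(=O)N[C@@H](CCc1ccccc1)C(=O)NCc1ccccc1`, which has not yet been measured. The change is (piperidin-1-yl)methyl in place of tert-butyl on a carbonyl carbon. In plain words, a (piperidin-1-yl)methyl group takes the place of tert-butyl on a carbonyl carbon whose other neighbour is an amide-type nitrogen; read one bond further out, a (tert-butyl)carbonyl becomes a ((piperidin-1-yl)methyl)carbonyl.

Among the compounds with values here, with no measured step to lean on, the expectation for the move from compound 2 to compound 3 in this assay is a change of about a 1.3-fold higher number from compound 2 to compound 3 (0.11 log units; within the scatter), which lies within the usual scatter rather than a clear shift in either direction. Compound 3 is therefore estimated at 80 nM, with a range from 25 nM to 300 nM.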

Compound 3, half-maximal inhibitory concentration: 62 nM
Estimate against measurement, compound 3: 1.3-fold (0.11 log units) above, and the stated range covers the measured number.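

In this assay, for the compounds shown here, putting (piperidin-1-yl)methyl in place of tert-butyl, on a carbonyl carbon whose other neighbour is an amide-type nitrogen, gives no change at the digits printed from compound 2 to compound 3 (within the scatter) and supplies the only measured step at this position. This shows that the position can take a cap of 7 heavy atoms with a six-membered non-aromatic ring and a nitrogen in place of one of 4 heavy atoms with no ring, and the reading stays the same in this pair. No measurement shown here accounts for the match between the two values.

From the compounds shown here alone, one pair cannot show how far this freedom extends, so it remains open whether a morpholin-4-ylmethyl group, a plain aminomethyl group, a carboxylic acid or a longer alkyl chain on the same carbonyl carbon would read the same. In this assay compound 1 gives "not determined" (no result reported) and so offers no comparison, which leaves the effect of changes elsewhere on the shared core open as well.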